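Replacing Bromo with Hydroxy in a Level Series

The source may hold more compounds than are shown below. What is called first, only, known or untested is meant among the compounds shown, and "the series" means these compounds.

In a functional assay on HT-1080 cells (Homo sapiens) for inhibition, read by colorimetric assay, with a stated time of 3 days (a higher number here means a weaker inhibitor, a lower number a stronger inhibitor), compound 1 (`COc1ccc(-c2cnc(NC(=O)CCCCCCNC(=O)C(O)(O)C(F)(F)F)s2)cc1`) gives 1960 nM and compound 2 (`O=C(CCCCCCNC(=O)C(O)(O)C(F)(F)F)Nc1ncc(-c2ccc(Br)cc2)s1`) gives 1760 nM while compound 3 (`COc1ccc2sc(NC(=O)CCCCCCNC(=O)C(O)(O)C(F)(F)F)nc2c1`) gives 2280 nM so compound 2 stands level with the other two, all within the usual scatter. Compound 4 (`O=C(CCCCCCNC(=O)C(O)(O)C(F)(F)F)Nc1ncc(-c2ccc(O)cc2)s1`) is compound 2 with hydroxy in place of bromo on an aromatic carbon. For the measured compounds named here, the one measured step at this same place puts bromo in place of methoxy (a 1.1-fold lower number from compound 1 to compound 2 (0.05 log units; within the scatter)) and stays within the scatter. Going by the values given here, no measurement yet shows what hydroxy does here, so only that small step can guide the forecast. The expected step (a 1.1-fold higher number from compound 2 to compound 4 (0.06 log units; within the scatter)) is therefore none beyond the scatter, in either direction. The estimate for compound 4 is 2000 nM (expected range 1000 nM to 4000 nM).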

Compound 4, half-maximal inhibitory concentration: 1420 nM
Estimate against measurement, compound 4: 1.4-fold (0.15 log units) above; measured number inside the range.
By their numbers in this assay, from the lowest: compounds 4, 2, 1 and 3 (each within the scatter of the next).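

In this assay hydroxy in place of bromo gives a 1.2-fold lower number from compound 2 to compound 4 (0.09 log units; within the scatter) and hydrogen in place of methyl on the oxygen gives a 1.4-fold lower number from compound 1 to compound 4 (0.14 log units; within the scatter) and both steps lie within the scatter. This position, para to a large group, has now carried bromo, methoxy and hydroxy without any step beyond the scatter, even though hydroxy adds a hydrogen-bond donor that bromo lacks. No evidence is available to explain this level result. Going by these compounds, whether an amine or a carboxylic acid here would shift the number beyond the scatter remains open.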